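Methyl on the ring amine of a bridged nicotinic agonist

The compounds below may be only part of what the source reports. "The series", "measured", "known", "first", "only" and "open" are said of these compounds alone.

Of the compounds shown here, three sharing a bridged bicyclic amine core have been measured in an in vitro functional assay on SH-SY5Y cells for agonist activity at Neuronal acetylcholine receptor; alpha3/beta4 (Homo sapiens), read by FLIPR and calcium flux; a higher number here means that more compound is needed for the effect, a lower number that less compound is needed. Compound 1 `Fc1ccc(C2=CC3CNCC(C2)C3)cn1` gives 99 nM. Compound 2 `C1=C(c2cncnc2)CC2CNCC1C2` gives 198 nM. Compound 3 `CC(C)Oc1cncc(C2=CC3CNCC(C2)C3)c1` gives 69 nM, the lowest of the three numbers; its gap to compound 1 lies within the scatter, whereas its gap to compound 2 lies beyond it, so compound 3 and compound 1 cannot be set in order against each other, while compound 2 needs more compound than either.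

Compound 4 `CC(C)Oc1cncc(C2=CC3CC(C2)CN(C)C3)c1` is not yet measured. It differs from compound 3 in one place: methyl in place of hydrogen on an amine nitrogen in a ring. Going by the values given here, no measured pair in this set shows the effect of such a change, so the expectation rests on the structural change alone and on where compound 3 stands.

Among the compounds with values here, the account expects the step of a 2.5-fold higher number from compound 3 to compound 4 (0.39 log units; beyond the scatter) to run toward a higher number, of a size somewhat beyond the scatter, since the unsubstituted amine nitrogen in a ring is shared by all three measured compounds and the methyl is the first departure from it. Compound 4 is therefore estimated at 170 nM, with a range from 55 nM to 550 nM.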

Compound 4, half-maximal effective concentration: > 10000 nM
Compound 4 ended at the assay's limit (the forecaster's own chance of this, stated with the estimate: 5%); middle value at least 58-fold (1.76 log units) away from the limit.
By their numbers in this assay, from the lowest: compounds 3, 1 and 2 (each within the scatter of the next, the first and the last beyond it). At a limit, above all of these: compound 4.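

In this assay the amine nitrogen in the ring proves to be a place where the smallest possible change counts: methyl in place of hydrogen there gives an at least 140-fold higher number from compound 3 to compound 4 (2.16 log units; beyond the scatter), a large step. Going by these compounds alone, the value of compound 4 is a limit of the assay and not a number, so this step gives only a lower bound on the change and its true size stays unknown: the limit of > 10000 nM in this assay, at which 1 of the 4 values shown sits. Compounds 1, 2 and 3 all carry hydrogen on this nitrogen, so they could say nothing about the position, and this single pair is the first reading of it.

As far as these compounds go, what stays open is whether the loss is particular to methyl or extends to other groups on the same nitrogen, such as ethyl, a longer chain or benzyl, and whether any of these would return a measurable number in this assay. It is also open whether methyl has the same effect on the cores of compound 1 and compound 2, since the one step shown carries the aromatic group of compound 3 alone, and the pair does not say what lies behind the change.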